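The source may report more compounds than this note shows. Statements on the series, on what has been measured and on what is new or still open speak of the compounds shown alone.

Measured so far in a functional assay on MIA PaCa-2 cells (Homo sapiens) for antiproliferative activity, read by sulforhodamine B assay, with a stated time of 48 h; a lower number here means a stronger inhibitor, a higher number a weaker inhibitor:
compound 1 `COc1cc(OC)c2sc(-c3ccc(N/C=C\C(=O)c4ccc(OC)c([N+](=O)[O-])c4)c(C)c3)nc2c1` gives 13900 nM;
compound 2 `COc1cc(OC)c2sc(-c3ccc(N/C=C\C(=O)c4cc(OC)c(OC)c([N+](=O)[O-])c4)c(C)c3)nc2c1` gives 10400 nM;
compound 3 `COc1cc(C(=O)/C=C\Nc2ccc(-c3nc4cc(OC)c(OC)c(OC)c4s3)cc2)cc([N+](=O)[O-])c1OC` gives 15800 nM.

Compound 1 and compound 2 share a core and differ in one place: hydrogen in place of methoxy on an aromatic carbon. That change produced a 1.3-fold higher number from compound 2 to compound 1 (0.13 log units; within the scatter). Compound 3 carries a different core; the difference between the two cores is not broken down here. The unmeasured compound 4 `COc1cc(OC)c2sc(-c3ccc(N/C=C\C(=O)c4cc(OC)c(OC)c([N+](=O)[O-])c4)cc3)nc2c1` is obtained from compound 3 by the same kind of change, (hydrogen in place of methoxy on an aromatic carbon), though the surroundings differ: here the carbon is part of a fused or bridged system of two rings, ortho to two methoxy groups, meta and para to a fused ring, rather than ortho to a methoxy group, meta to a large group and meta to a nitro group. Among the compounds with values here, the one earlier step of this kind stayed within the scatter, so a similar small step a 1.1-fold lower number from compound 3 to compound 4 (0.05 log units; within the scatter) is expected, resting on a 1.3-fold higher number from compound 2 to compound 1 (0.13 log units; within the scatter) and on compound 3 at 15800 nM. For compound 4 in this assay the estimate is 14000 nM, between 6000 nM and 33000 nM.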

Compound 4, half-maximal inhibitory concentration: 12700 nM
For compound 4 the middle estimate is 1.1-fold (0.04 log units) above the measured one, within the range that was stated.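

In this assay, hydrogen in place of methoxy on an aromatic carbon gives a 1.2-fold lower number from compound 3 to compound 4 (0.09 log units; within the scatter), and loss of a methyl group gives a 1.2-fold higher number from compound 2 to compound 4 (0.09 log units; within the scatter). Set side by side, the methoxy change on the two cores agrees as far as these numbers can tell: the same change on two cores in this assay, a 1.3-fold higher number (0.13 log units; within the scatter) from compound 2 to compound 1 and a 1.2-fold lower number (0.09 log units; within the scatter) from compound 3 to compound 4, 1.7-fold (0.22 log units) apart, within the scatter of two such steps. This shows that the change stayed inside the scatter on both cores, but it does not give a real size that could be carried to a further core, and two cores are too few for a rule.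

From the compounds shown here alone, whether any change moves the number beyond the scatter remains open. An amine or a carboxylic acid in place of the nitro group, for example, lies outside the compounds shown, so its step is unknown.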